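The source may hold more compounds than are shown below. What is called first, only, known or untested is meant among the compounds shown, and "the series" means these compounds.

Two compounds have been measured in a functional assay on the whole organism for inhibition, with Rattus norvegicus as the target, at a dose of 10 mg/kg by the oral route; on this read-out higher numbers stand for a stronger effect at the one dose given and lower numbers for a weaker effect:
compound 1 `COc1cc(C(=O)Nc2nn[nH]n2)nc(-c2cccc(Cl)c2)c1` gives 64%
compound 2 `COc1cc(C(=O)Nc2nn[nH]n2)nc(-c2ccc(Cl)cc2)c1` gives 55%

Within the data shown here, compound 2 gives the smaller of these two numbers, yet the only step between them, a number 9 percentage points lower from compound 1 to compound 2 (within the scatter), lies within the usual scatter, so on the numbers at hand compound 2 and compound 1 cannot be told apart in this assay.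

Compound 3 `COc1cc(C(=O)Nc2nn[nH]n2)nc(-c2ccc(NC(C)=O)cc2)c1` is the next compound and has not yet been measured. It differs from compound 2 in one place: acetamido in place of chloro on an aromatic carbon. Among the measured compounds shown here, the one measured step, from compound 1 to compound 2, concerns a move of chloro from one position on the same ring to another and leaves the chloro itself untouched; no measured pair exchanges chloro for acetamido or for any other group. That step therefore gives no guide to the present change, and there is nothing in the data to set a direction for it. Compound 3 is accordingly expected to stay near compound 2, with a wide band of uncertainty. The step from compound 2 to compound 3 is estimated at a number 5 percentage points lower from compound 2 to compound 3 (within the scatter). Compound 3 is estimated to give 50% in this assay, within a range from 20% to 80%.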

Compound 3, a percentage reported as inhibition, in the whole organism at one dose (the size of the read-out at that dose, not a potency): 100%
The estimate for compound 3 lay 50 percentage points below the measured number; the whole stated range lies below it.
By their numbers in this assay, from the lowest: compounds 2 and 1 (each within the scatter of the next); then compound 3.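

Among these compounds, the exchange of chloro for acetamido on this aromatic carbon, para to a large group, gives a number 45 percentage points higher from compound 2 to compound 3 (beyond the scatter) in this assay and is the first change to lie beyond the scatter. The earlier compounds shown here offered only a shift of chloro on the ring, a number 9 percentage points lower from compound 1 to compound 2 (within the scatter), so they could not show that the number depends strongly on which group occupies this place. Compound 3 therefore stands clearly apart from compound 2 , yet nothing measured here explains the size of this step.

The compounds shown do not reveal which part of the acetamido group matters, and a plain amine, a propionamido group with its longer chain, or a carboxylic acid at this place would help to separate the amide hydrogen, the carbonyl and the chain. On these data alone, it also remains open whether acetamido placed where compound 1 carries its chloro would behave in the same way, and the number for compound 3 gives the size of the effect at one dose, not a potency.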